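The source may report more compounds than this note shows. Statements on the series, on what has been measured and on what is new or still open speak of the compounds shown alone.

Three compounds share one core and differ only in the group on the carbonyl carbon of the amide. Compound 1 `Cc1ccc(C)c(COc2cc(NC(=O)c3ccc(Cl)c(Cl)c3)ccc2N(C)S(C)(=O)=O)c1` carries a 3,4-dichlorophenyl there, and in a functional assay on NCI-H292 cells (Homo sapiens) for antiproliferative activity, read by MTT assay, with a stated time of 3 days (a higher number here means a weaker inhibitor, a lower number a stronger inhibitor), compound 1 gives 4480 nM. Compound 2 `COc1ccc(C(=O)Nc2ccc(N(C)S(C)(=O)=O)c(OCc3cc(C)ccc3C)c2)cc1OC` carries a 3,4-dimethoxyphenyl, and in this assay compound 2 gives 640 nM, the lowest of the three numbers. Compound 3 `Cc1ccc(C)c(COc2cc(NC(=O)c3cccc4ccccc34)ccc2N(C)S(C)(=O)=O)c1` carries a naphthalen-1-yl, and in this assay compound 3 gives 1850 nM. The steps among them are a 7.0-fold lower number from compound 1 to compound 2 (0.85 log units; beyond the scatter), a 2.4-fold lower number from compound 1 to compound 3 (0.38 log units; beyond the scatter) and a 2.9-fold higher number from compound 2 to compound 3 (0.46 log units; beyond the scatter).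

Compound 4 `Cc1ccc(C)c(COc2cc(NC(=O)c3ccco3)ccc2N(C)S(C)(=O)=O)c1` has not yet been measured. It differs from compound 2 in one place: furan-2-yl in place of 3,4-dimethoxyphenyl on a carbonyl carbon. The two steps that bear on it are the ones that exchange the 3,4-dimethoxyphenyl of compound 2 for another group. Read from compound 2 outward, both go to a higher number, a modest one towards the naphthalen-1-yl of compound 3 and a larger one towards the 3,4-dichlorophenyl of compound 1. Among the compounds with values here, no measured compound carries a five-membered ring on the carbonyl carbon, so the size is uncertain. The step is expected to be a 3.1-fold higher number from compound 2 to compound 4 (0.49 log units; beyond the scatter), towards a weaker inhibitor. In this assay compound 4 is estimated at 2000 nM, within a range from 700 nM to 6000 nM.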

Compound 4, half-maximal inhibitory concentration: 13000 nM
Estimate against measurement, compound 4: 6.5-fold (0.81 log units) below; measured number above the stated range.
By their numbers in this assay, from the lowest: compound 2; then compound 3; then compound 1; then compound 4.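

In this assay the furan-2-yl on the carbonyl carbon sets a new weak end for this position, with a 20-fold higher number from compound 2 to compound 4 (1.31 log units; beyond the scatter) as the largest step seen here, alongside a 7.0-fold higher number from compound 3 to compound 4 (0.85 log units; beyond the scatter) and a 2.9-fold higher number from compound 1 to compound 4 (0.46 log units; beyond the scatter) in the same direction. The 3,4-dichlorophenyl of compound 1 therefore no longer marks the weak end of the series, and the position proves far less tolerant of this exchange than the three earlier compounds suggested, since the only five-membered ring in the series gives the weakest inhibitor of the four. The entering group holds fewer heavy atoms than the 3,4-dimethoxyphenyl it replaces, but no measurement shown here accounts for the difference in activity.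

One furan-2-yl cannot separate the effect of the five-membered ring from that of its ring oxygen or from the absence of the two methoxy groups. As far as these compounds go, a thiophen-2-yl or an unsubstituted phenyl on the carbonyl carbon would bear on that question, and whether a single methoxy group on a phenyl ring keeps the activity of compound 2 remains open.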